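Taking one bromo off compound 2

The source may report more compounds than this note shows. Statements on the series, on what has been measured and on what is new or still open speak of the compounds shown alone.

In an ADME assay on BMDM cells (Mus musculus) for cytotoxicity, read by MTT assay, with a stated time of 72 h (on this read-out lower numbers stand for stronger inhibition and higher numbers for weaker inhibition), compound 1 `CC[C@H]1C[C@@]23OC(=O)C(=C2O)C(=O)[C@]2(CC)[C@@H](C=C[C@@H]4[C@@H](O[C@H]5C[C@@H](O)[C@H](NC(=O)c6[nH]c(Cl)cc6Cl)[C@@H](C)O5)[C@@H](C)CC[C@@H]42)CCCC/C=C/[C@@]3(C)C=C1C(=O)O` gives 50000 nM, while compound 2 `CC[C@H]1C[C@@]23OC(=O)C(=C2O)C(=O)[C@]2(CC)[C@@H](C=C[C@@H]4[C@@H](O[C@H]5C[C@@H](O)[C@H](NC(=O)c6[nH]cc(Br)c6Br)[C@@H](C)O5)[C@@H](C)CC[C@@H]42)CCCC/C=C/[C@@]3(C)C=C1C(=O)O` gives 109000 nM, the higher of the two numbers and so the weaker inhibition. Compound 3 `CC[C@H]1C[C@@]23OC(=O)C(=C2O)C(=O)[C@]2(CC)[C@@H](C=C[C@@H]4[C@@H](O[C@H]5C[C@@H](O)[C@H](NC(=O)c6[nH]ccc6Br)[C@@H](C)O5)[C@@H](C)CC[C@@H]42)CCCC/C=C/[C@@]3(C)C=C1C(=O)O` keeps the shared core and departs from compound 2 by hydrogen in place of bromo on an aromatic carbon. Among the measured compounds shown here, only one measured step bears on this change: a 2.2-fold higher number from compound 1 to compound 2 (0.34 log units; beyond the scatter), a modest step beyond the scatter that exchanged a dichloro group for a dibromo group. For the measured compounds named here, no measured step removes a halogen outright, so this evidence is indirect and gives no firm direction. A shift no larger than that modest step is therefore expected in this assay, and quite possibly none beyond the scatter. The expected step is a 1.1-fold lower number from compound 2 to compound 3 (0.04 log units; within the scatter), which stays within the scatter. For compound 3 the estimated value is 100000 nM, with an expected range from 45000 nM to 220000 nM.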

Compound 3, half-maximal inhibitory concentration: 143000 nM
For compound 3 the middle estimate is 1.4-fold (0.16 log units) below the measured one, and the stated range covers the measured number.
By their numbers in this assay, from the lowest: compound 1; then compounds 2 and 3 (each within the scatter of the next).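

In this assay, hydrogen in place of bromo on this aromatic carbon gives a 1.3-fold higher number from compound 2 to compound 3 (0.12 log units; within the scatter) and so stays within the scatter, which shows that the bromo at this position can be removed outright without a clear change in this read-out. The group bearing a single bromo, set against the dichloro group of compound 1, gives a 2.9-fold higher number from compound 1 to compound 3 (0.46 log units; beyond the scatter) as a modest step beyond the scatter, and compound 1 therefore keeps the lowest number of the three. Nothing measured here offers an explanation for either step.

Because compound 1 and compound 2 differ in both the kind of halogen and where it sits, the compounds shown do not separate these two changes. Going by these compounds, it also remains open whether a methyl group or an amine on this aromatic carbon would move the number beyond the scatter.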